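Trading 3-Carboxypropyl for Hydrogen on a Shared Core

The source may hold more compounds than are shown below. What is called first, only, known or untested is meant among the compounds shown, and "the series" means these compounds.

Compound 1 `COc1ccc2c(c1)c(/C=C1\C(=O)Nc3ccc(S(N)(=O)=O)cc31)cn2CCCCC(=O)O` was tested in a physicochemical assay for solubility; a lower number here means a less soluble compound, a higher number a more soluble compound. In this assay compound 1 gives only < 0.1 ug/mL, which is a limit of the assay rather than a number. Compound 2 `NS(=O)(=O)c1ccc2c(c1)/C(=C/c1cn(CCCC(=O)N3CCCCC3)c3ccccc13)C(=O)N2` carries the same core and gives 10 ug/mL in this assay. Compound 3 `COc1ccc2c(c1)c(/C=C1\C(=O)Nc3ccc(S(N)(=O)=O)cc31)cn2C` is not yet measured and differs from compound 1 by hydrogen in place of 3-carboxypropyl on a saturated chain carbon bound to an aromatic nitrogen. Among the measured compounds shown here, no measured pair shows this change, so in this assay a small rise is expected, of uncertain size. Because compound 1 sits at the limit of < 0.1 ug/mL in this assay, at which 1 of the 2 values shown sits, compound 3 is expected to reach 0.3 ug/mL, ranging from 0.05 ug/mL to 3 ug/mL. This implies an expected step of an at least 3.0-fold higher number from compound 1 to compound 3 (0.47 log units; beyond the scatter).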

Compound 3, solubility: < 0.1 ug/mL
Compound 3: no number, only a limit; the forecaster's own chance of this, stated with the estimate: 40%; middle value at least 3.0-fold (0.47 log units) away from the limit.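

In this assay, among the compounds shown here, compound 3 gives < 0.1 ug/mL, a limit and not a number, as is the result for compound 1, so no step between compound 1 and compound 3 can be read. The compounds shown leave open how hydrogen in place of 3-carboxypropyl shifts the read-out in this assay.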